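This account rests on a few compounds, and the source may have more. Where it says the series, first, only, none or still open, it means among the compounds named here.

Measured so far in a functional assay on MCF7 cells (Homo sapiens) for cytotoxicity; a higher number here means a weaker inhibitor, a lower number a stronger inhibitor:
compound 1, `COc1ccc(Cn2cc(/C=N\NC(=O)c3c[nH]c4ccc(Br)cc34)c3cc(OC)ccc32)cc1` — 3100 nM
compound 2, `O=C(N/N=C\c1cn(Cc2ccc(Cl)cc2)c2cc(F)ccc12)c1c[nH]c2ccccc12` — 6000 nM

Within the data shown here, compound 2 has the higher of the two numbers in this assay, but its only neighbour is compound 1, and the gap between the two lies within the scatter, so no order between them can be claimed. Compound 3, `Cn1cc(C(=O)N/N=C\c2cn(Cc3ccc(Cl)cc3)c3cc(F)ccc23)c2ccccc21`, differs from compound 2 in one place: methyl in place of hydrogen on an aromatic nitrogen of a five-membered aromatic ring with one nitrogen, part of a fused system of two rings; cut one bond further out, the change reads 1H-indol-3-yl to 1-methyl-1H-indol-3-yl. Among the measured compounds shown here, no pair of measured compounds carries this change, so nothing shows its size or direction. Expected is a step of no change at the digits printed from compound 2 to compound 3 (within the scatter), no larger than the scatter in either direction. For compound 3 the estimate in this assay is 6000 nM, between 2500 nM and 15000 nM.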

Compound 3, half-maximal inhibitory concentration: 90600 nM
The estimate for compound 3 lay 15-fold (1.18 log units) below the measured number; measured number above the stated range.
By their numbers in this assay, from the lowest: compounds 1 and 2 (each within the scatter of the next); then compound 3.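

Among these compounds, the hydrogen on the aromatic nitrogen of the 1H-indol-3-yl group is the first place where a single change can be sized: in this assay, methyl in place of that hydrogen gives a 15-fold higher number from compound 2 to compound 3 (1.18 log units; beyond the scatter) and marks the change as large. One added carbon at this nitrogen is therefore enough to shift the number well beyond the scatter towards weaker inhibition, and the hydrogen cannot be replaced by methyl here without that loss. The evidence at hand gives no reason for the step.

From the compounds shown here alone, whether the same step appears on the core of compound 1 remains open. An ethyl or acetyl group on this nitrogen would show whether the loss follows from methyl alone or from any replacement of the hydrogen.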